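Methyl to trifluoromethyl in a series at its limit

The source may report more compounds than this note shows. Statements on the series, on what has been measured and on what is new or still open speak of the compounds shown alone.

In a functional assay on MCF7 cells (Homo sapiens) for antiproliferative activity, with a stated time of 96 h (on this read-out lower numbers stand for stronger inhibition and higher numbers for weaker inhibition), compound 1 (`Cc1cc(=O)oc2cc(OCC(=O)c3ccc(F)cc3)ccc12`) gives > 100000 nM as a limit of the assay. Compound 2 (`Cc1cc(=O)oc2cc(OCC(=O)c3ccc(OC(F)(F)F)cc3)ccc12`) gives > 100000 nM and this too is only a limit. Compound 3 (`Cc1cc(=O)oc2cc(OCC(=O)c3ccc(C(F)(F)F)cc3)ccc12`) gives > 100000 nM as a limit again. Compound 2 therefore has no number, and the series stands at the limit of > 100000 nM in this assay, at which 3 of the 3 values shown sit, with nothing resolved so far.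

Compound 4 (`O=C(COc1ccc2c(C(F)(F)F)cc(=O)oc2c1)c1ccc(OC(F)(F)F)cc1`) is reached from compound 2 by one change (trifluoromethyl in place of methyl on an aromatic carbon), trifluoromethyl in place of methyl on an aromatic carbon, opposite the ring oxygen. The measured steps exchange a different group and give no size: one is a step that the two limits leave unreadable from compound 1 to compound 2 and one is a step that the two limits leave unreadable from compound 1 to compound 3 and one is a step that the two limits leave unreadable from compound 2 to compound 3 in the same way.

The expectation rests on compound 2 with > 100000 nM as a limit, so no direction can be argued and no clear gain is foreseen. The expected change is an at least 1.1-fold lower number from compound 2 to compound 4 (0.04 log units; that floor lies within the scatter) at most a small one. Compound 4 is estimated at 90000 nM with an expected range from 30000 nM to 100000 nM and will probably be reported as a limit again.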

Compound 4, half-maximal inhibitory concentration: "not active" (no number reported)
No number was reported for compound 4; the estimate stays without a comparison.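

In this assay, among these compounds, compound 4 stands as "not active" (no number reported), with no number, so no step from compound 2 to compound 4 can be read. Compound 2 gives > 100000 nM, which is a limit. The compounds shown leave open whether any change on the shared core gives a measurable value in this assay.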